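The compounds below may be only part of what the source reports. "The series", "measured", "known", "first", "only" and "open" are said of these compounds alone.

Measured in an assay on isolated protein for inhibition of protein deacetylase HDAC6 (Homo sapiens), read by fluorescence, with a stated time of 1 h, tested at 100 nM; a lower number here means less inhibition, a higher number more inhibition at the concentration tested (going by the name of the read-out):

compound 1 `O=C(/C=C/c1ccc(OCc2nc(C3CCN(Cc4ccccc4Cl)CC3)no2)cc1)NO`: 59%
compound 2 `N#Cc1ccc(CN2CCC(c3noc(COc4ccc(/C=C/C(=O)NO)cc4)n3)CC2)cc1`: 65%
compound 3 `CN(Cc1nc(C2CCN(Cc3ccccc3Cl)CC2)no1)c1ncc(C(=O)NO)cn1`: 55%

Compounds 1 and 2 share one core; compound 3 has a different core, and the difference between the two cores is not broken down here. The change from compound 1 to compound 2 is 4-cyanophenyl in place of 2-chlorophenyl on a saturated chain carbon bound to an amine nitrogen in a ring and gave a number 6 percentage points higher from compound 1 to compound 2 (within the scatter) in this assay. Compound 4 `CN(Cc1nc(C2CCN(Cc3ccc(C#N)cc3)CC2)no1)c1ncc(C(=O)NO)cn1` is not yet measured; it stands to compound 3 as compound 2 stands to compound 1, the change being (4-cyanophenyl in place of 2-chlorophenyl on a saturated chain carbon bound to an amine nitrogen in a ring). The place of the change is the same in both pairs, so this is the same change.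

Because the earlier step was a number 6 percentage points higher from compound 1 to compound 2 (within the scatter), a step of similar size is expected here, namely a number 6 percentage points higher from compound 3 to compound 4 (within the scatter). Compound 4 is therefore estimated at 61% in this assay, with a likely span from 48% to 74%.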

Compound 4, a percentage reported as inhibition, at one concentration (the size of the read-out at that concentration, not a potency): 38%
Compound 4: the middle estimate sits 23 percentage points above what was measured; measured number outside the range, below it.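

In this assay, the change from 2-chlorobenzyl to 4-cyanobenzyl on the core of compound 3 gave a number 17 percentage points lower from compound 3 to compound 4 (beyond the scatter), and it did not carry over between the two cores: the same change on two cores in this assay, a number 6 percentage points higher (within the scatter) from compound 1 to compound 2 and a number 17 percentage points lower (beyond the scatter) from compound 3 to compound 4, 23 percentage points apart, beyond the scatter of two such steps. In these two pairs, the outcome of the change therefore depends on the core, but the difference between the cores is not broken down, so no part of the core can be held responsible. With a single pair on each core, this shows no general rule for either core.

Going by these compounds, it remains open whether the lower number for compound 4 follows from gaining the nitrile or from losing the chlorine. A plain benzyl group on both cores would help separate the two.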